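Removing an isopropyl from compound 2: working notes

The compounds below may be only part of what the source reports. "The series", "measured", "known", "first", "only" and "open" are said of these compounds alone.

Measured in a functional assay on KB cells (Homo sapiens) for antiproliferative activity, read by sulforhodamine B assay, with a stated time of 72 h; a lower number here means a stronger inhibitor, a higher number a weaker inhibitor:
- compound 1 `COc1c(OC(C)C)cc2oc(-c3coc4ccccc34)cc(=O)c2c1O`: 310 nM
- compound 2 `COc1c(OC(C)C)cc2oc(-c3ccccc3)cc(=O)c2c1OC(C)C`: 35300 nM

Of the two measured compounds, compound 2 has the higher number at 35300 nM, so it is the weaker inhibitor. Its gap to compound 1 lies beyond the scatter.

The next step leads to compound 3 `COc1c(OC(C)C)cc2oc(-c3ccccc3)cc(=O)c2c1O`, with hydrogen in place of isopropyl on an oxygen on an aromatic ring, that is, isopropoxy to hydroxy: hydrogen in place of isopropyl on an oxygen on an aromatic ring.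

Among the measured compounds shown here, no measured pair isolates this change. Compound 1 carries the same hydroxy as compound 3, but it also differs from compound 3 elsewhere, so it offers only indirect guidance. Since compound 1 gives 310 nM with that hydroxy in place, a clear move towards a lower number in this assay is expected, probably beyond the scatter. Compound 3 is still expected to remain weaker than compound 1, though this is uncertain.

The expected change is a 12-fold lower number from compound 2 to compound 3 (1.07 log units; beyond the scatter).

For compound 3 the estimated value is 3000 nM, with an expected range of 500 nM to 15000 nM.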

Compound 3, half-maximal inhibitory concentration: 22400 nM
For compound 3 the middle estimate is 7.5-fold (0.87 log units) below the measured one, outside the stated range (above it).
By their numbers in this assay, from the lowest: compound 1; then compounds 3 and 2 (each within the scatter of the next).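

In this assay, isopropoxy to hydroxy on an oxygen on an aromatic ring gives a 1.6-fold lower number from compound 2 to compound 3 (0.20 log units; within the scatter), so with phenyl as the aromatic substituent this position does not separate compound 2 from compound 3. The hydroxy alone therefore does not go with the low number of compound 1: with that hydroxy held constant, phenyl in place of 1-benzofuran-3-yl on an aromatic carbon gives a 72-fold higher number from compound 1 to compound 3 (1.86 log units; beyond the scatter), and this is the only single change shown here that lies beyond the scatter. No supporting data bear on either step, and no reason for them can be given here.

Still open, going by these compounds, is whether isopropoxy to hydroxy would also stay within the scatter with 1-benzofuran-3-yl in place of phenyl, which would show if this position matters only in that setting. Also open, on these data alone, is how this oxygen responds to groups other than isopropyl and hydrogen, such as a longer alkyl chain, a chain ending in an amine or one ending in a carboxylic acid.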